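Formyl replacing hydroxy(phenyl)methyl in a weak series

This account rests on a few compounds, and the source may have more. Where it says the series, first, only, none or still open, it means among the compounds named here.

Measured so far:
compound 1, `Cc1ccc(S(=O)(=O)Oc2c(-c3ccccc3)c(-c3ccccc3)n3ccc(C#N)cc23)cc1`, 25000 nM
compound 2, `N#Cc1ccn2c(-c3ccccc3)c(-c3ccccc3)c(C(O)c3ccccc3)c2c1`, 48000 nM

In an assay for inhibition of Polyunsaturated fatty acid lipoxygenase ALOX15 (Oryctolagus cuniculus) (a higher number here means a weaker inhibitor, a lower number a stronger inhibitor), compound 2 holds the highest of the two numbers; its nearest neighbour is compound 1, and a 1.9-fold higher number from compound 1 to compound 2 (0.28 log units; within the scatter). Compound 3, `N#Cc1ccn2c(-c3ccccc3)c(-c3ccccc3)c(C=O)c2c1`, is unmeasured; it differs from compound 2 by formyl in place of hydroxy(phenyl)methyl on an aromatic carbon. For the measured compounds named here, the only step at this position, from compound 1 to compound 2, stayed within the scatter, so no step beyond the scatter is expected in this assay for compound 3, in either direction. Compound 3 is estimated at 40000 nM, range 15000 nM to 120000 nM, meaning an expected 1.2-fold lower number from compound 2 to compound 3 (0.08 log units; within the scatter).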

Compound 3, half-maximal inhibitory concentration: 61000 nM
Estimate against measurement, compound 3: 1.5-fold (0.18 log units) below; low and high end bracket the measured number.
By their numbers in this assay, from the lowest: compounds 1, 2 and 3 (each within the scatter of the next, the first and the last beyond it).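

In this assay, trimming hydroxy(phenyl)methyl to formyl removes the six-membered aromatic ring and the hydrogen-bond donor, yet gives a 1.3-fold higher number from compound 2 to compound 3 (0.10 log units; within the scatter) and so leaves the number unmoved. Formyl in place of ((4-methylphenyl)sulfonyl)oxy gives a 2.4-fold higher number from compound 1 to compound 3 (0.39 log units; beyond the scatter) as the only step at this position beyond the scatter, and it is a modest one. No evidence on hand bears on this result.

From the compounds shown here alone, whether an amine, a carboxylic acid or a longer chain on this aromatic carbon would give a clearly stronger inhibitor remains open.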